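Removing a Methoxy Group on a Cytotoxic Scaffold

The compounds below may be only part of what the source reports. "The series", "measured", "known", "first", "only" and "open" are said of these compounds alone.

Compound 1 `N#C/C(=C\c1c[nH]c2cc(F)ccc12)C(=O)c1c[nH]c2ccccc12`, compound 2 `COc1ccc2[nH]cc(C(=O)/C(C#N)=C/c3c[nH]c4cc(F)ccc34)c2c1` and compound 3 `COc1ccc2c(C(=O)/C(C#N)=C/c3c[nH]c4ccc(OC)cc34)c[nH]c2c1` were tested in a functional assay on MIA PaCa-2 cells (Homo sapiens) for cytotoxicity, read by WST assay, with a stated time of 48 h; on this read-out lower numbers stand for stronger inhibition and higher numbers for weaker inhibition. Compound 1 gives 31600 nM. For compound 2 only a limit of > 50000 nM was recorded. For compound 3 the result is likewise only a limit of > 50000 nM. The difference between the cores of compound 2 and compound 3 is not broken down here. Compound 1 and compound 2 differ in one place, (hydrogen in place of methoxy on an aromatic carbon), and this change produced an at least 1.5-fold lower number from compound 2 to compound 1 (0.19 log units; that floor lies within the scatter). In judging that step it matters that it rests on (the limit of > 50000 nM in this assay, at which 2 of the 3 values shown sit), so it is a floor rather than a full number. Compound 4 `COc1ccc2c(C(=O)/C(C#N)=C/c3c[nH]c4ccccc34)c[nH]c2c1` is still to be measured in this assay; it arises from compound 3 by the same change, (hydrogen in place of methoxy on an aromatic carbon). Because the measured step of the same kind was an at least 1.5-fold lower number from compound 2 to compound 1 (0.19 log units; that floor lies within the scatter), a similar shift is expected for compound 4, namely an at least 1.2-fold lower number from compound 3 to compound 4 (0.09 log units; that floor lies within the scatter). Compound 4 is therefore estimated at about 40000 nM, with a range from 15000 nM to 100000 nM, and there is a fair chance that again only a limit is recorded.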

Compound 4, half-maximal inhibitory concentration: > 50000 nM
Compound 4 ended at the assay's limit; the forecaster's own chance of this, stated with the estimate: 50%; at least 1.2-fold (0.09 log units) between middle value and limit.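

The step from compound 3 to compound 4 cannot be read, because each of the two compounds carries only a limit rather than a full number: the limit of > 50000 nM in this assay, at which 3 of the 4 values shown sit. The compounds shown leave open whether hydrogen in place of methoxy on an aromatic carbon changes the cytotoxicity of compound 3 at all.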